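The source may hold more compounds than are shown below. What is called first, only, known or untested is meant among the compounds shown, and "the series" means these compounds.

Measured compounds in a functional assay on HT-29 cells (Homo sapiens) for cytotoxicity, read by MTT assay, with a stated time of 72 h; a higher number here means a weaker inhibitor of growth, a lower number a stronger inhibitor of growth:

compound 1 `C[Se]/C(=N\C(=O)c1cccs1)NC(=O)c1cccs1`: > 100000 nM
compound 2 `O=C(/N=C(/NC(=O)c1ccno1)[Se]Cc1ccccc1)c1ccno1`: > 100000 nM
compound 3 `O=C(/N=C(/NC(=O)c1cccs1)[Se]Cc1ccccc1)c1cccs1`: > 100000 nM

Each of these three values is a limit of this assay and not a number. Compound 1 sits at that limit. Compound 2 sits at that limit as well. Compound 3 likewise gives only a limit. For the measured compounds named here, the one change made between measured compounds, (hydrogen in place of phenyl on a saturated chain carbon bound to a selenium atom), yields a step, a step that the two limits leave unreadable from compound 3 to compound 1, that cannot be read because the limit of > 100000 nM in this assay, at which 3 of the 3 values shown sit: both ends of the pair are at the limit.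

Compound 4 `C[Se]/C(=N\C(=O)c1ccno1)NC(=O)c1ccno1` is not yet measured in this assay. It stands to compound 2 as compound 1 stands to compound 3: the difference is hydrogen in place of phenyl on a saturated chain carbon bound to a selenium atom, the same kind of change at the same place, a saturated chain carbon bound to a selenium atom. How the core of compound 2 differs from the core of compound 3 is not broken down here.

The expected step from compound 2 to compound 4 in this assay is estimated as a step that the limit leaves unreadable from compound 2 to compound 4, resting on the observation that compound 3 and compound 1 both sit at the limit of > 100000 nM in this assay, at which 3 of the 3 values shown sit, so the same change is expected to leave compound 4 at or near the same limit. For compound 4 the estimate is 150000 nM, with a range from 50000 nM to 500000 nM, and it is expected that this assay most likely again reports only a limit.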

Compound 4, concentration for total growth inhibition: > 100000 nM
Compound 4: no number, only a limit (the forecaster's own chance of this, stated with the estimate: 85%); the middle value does not contradict the limit.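

In this assay compound 4 gives > 100000 nM as a limit and not a number. No step can therefore be read between compound 2 and compound 4, because both compounds sit at the same limit: the limit of > 100000 nM in this assay, at which 4 of the 4 values shown sit.

The compounds shown leave open whether any compound in this series gives a readable value, and what benzyl to methyl does to such a value.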